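Halogen shift on the aryl group of a translocator protein ligand

The compounds below may be only part of what the source reports. "The series", "measured", "known", "first", "only" and "open" are said of these compounds alone.

Compound 1 `CN(Cc1ccccc1)C(=O)c1nc(-c2ccccc2)c2ccccc2n1`: 3.99 nM
Compound 2 `CN(Cc1ccccc1)C(=O)c1nc(-c2ccccc2F)c2ccccc2n1`: 1.11 nM

Both compounds were tested in an assay on cell membranes from kidney for displacement of a labelled ligand from Translocator protein (Rattus norvegicus); on this read-out higher numbers stand for weaker inhibition and lower numbers for stronger inhibition. Compound 1 `CN(Cc1ccccc1)C(=O)c1nc(-c2ccccc2)c2ccccc2n1` gives 3.99 nM, and compound 2 `CN(Cc1ccccc1)C(=O)c1nc(-c2ccccc2F)c2ccccc2n1` gives 1.11 nM. Within the data shown here, the only step between measured compounds is a 3.6-fold lower number from compound 1 to compound 2 (0.56 log units; beyond the scatter), a modest but real improvement. On these two numbers compound 2 stands lowest; its nearest neighbour is compound 1, whose higher number lies beyond the scatter.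

Compound 3 `CN(Cc1ccccc1)C(=O)c1nc(-c2ccc(Cl)cc2)c2ccccc2n1` has not been measured. It differs from compound 2 in one place: 4-chlorophenyl in place of 2-fluorophenyl on an aromatic carbon. The step from compound 1 to compound 2 bears on this only in part: it shows that a 2-fluorophenyl group in this position gives a lower number than plain phenyl, but says nothing about a 4-chlorophenyl group. Since compound 3 gives up the fluorine that produced that step, a modest rise in number is expected, a 2.7-fold higher number from compound 2 to compound 3 (0.43 log units; beyond the scatter), putting compound 3 somewhere near compound 1. For compound 3 an estimate of 3 nM, with a range from 1 nM to 10 nM, is expected.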

Compound 3, inhibition constant: 6.12 nM
For compound 3 the middle estimate is 2.0-fold (0.31 log units) below the measured one; low and high end bracket the measured number.
By their numbers in this assay, from the lowest: compound 2; then compounds 1 and 3 (each within the scatter of the next).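

In this assay the change to 4-chlorophenyl gives a 5.5-fold higher number from compound 2 to compound 3 (0.74 log units; beyond the scatter), so the lower number seen with 2-fluorophenyl does not carry over to every halogen-bearing phenyl group at this place on the shared core. Set against plain phenyl, the chloro group gives a 1.5-fold higher number from compound 1 to compound 3 (0.19 log units; within the scatter), which leaves compound 3 indistinguishable from compound 1 on this read-out; a halogen on the phenyl group is therefore not enough on its own, and of the two halogen-bearing groups only 2-fluorophenyl stands apart from plain phenyl. Nothing available here explains why these two groups behave differently.

The step to compound 3 changes both the halogen and where it sits on the phenyl group, so the compounds shown cannot say which of the two changes matters. On these data alone, a 2-chlorophenyl group and a 4-fluorophenyl group would separate those two changes, and how a methoxy group or an amine would read on the same phenyl group remains open.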